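A few compounds are considered here, and "the series" means these few. Any claim that something is new, unique, unknown or untested is made for them only; others in the source may bear on it.

Two measured compounds set the scene. Compound 1 `Cc1noc(Cn2nc3ccc(-c4ccc(Oc5ccc(F)cc5)cc4)cn3c2=O)n1` and compound 2 `Cc1nc(Cn2nc3ccc(-c4ccc(Oc5ccc(Cl)cc5)cc4)cn3c2=O)no1` share a common core and differ in the halogen at the far end and in the arrangement of the small five-membered ring on the side chain. In an ADME assay on microsomes (Rattus norvegicus) for metabolic stability (a higher number here means that the compound lasts longer, a lower number that the compound disappears faster), compound 1 gives 1.42 h and compound 2 gives 6.5 h. Among the compounds with values here, compound 1 thus stands lowest of the two numbers, with compound 2 lying beyond the usual scatter above it, though the two differ in more than one place and no single step connects them.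

The compound now in question is compound 3 `O=c1[nH]nc2ccc(-c3ccc(Oc4ccc(F)cc4)cc3)cn12`. It differs from compound 1 only in one place: hydrogen in place of (3-methyl-1,2,4-oxadiazol-5-yl)methyl on an aromatic nitrogen. Nothing measured shows what removing this side chain does in this assay, so the direction of the step is open. Taking compound 1 at 1.42 h as the anchor, the step from compound 1 to compound 3 is expected to be small, a 1.4-fold higher number from compound 1 to compound 3 (0.15 log units; within the scatter), possibly within the scatter. Compound 3 is therefore estimated at 2 h, with a range from 0.8 h to 5 h.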

Compound 3, half-life: 0.717 h
The estimate for compound 3 lay 2.8-fold (0.45 log units) above the measured number; the whole stated range lies above it.
By their numbers in this assay, from the lowest: compounds 3 and 1 (each within the scatter of the next); then compound 2.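

Replacing the (3-methyl-1,2,4-oxadiazol-5-yl)methyl group on the aromatic nitrogen with a hydrogen atom gives a 2.0-fold lower number from compound 1 to compound 3 (0.30 log units; within the scatter) in this assay, so this step cannot be told apart from the ordinary spread of repeated measurements. The earlier compounds shown here could not show this, since compound 1 and compound 2 differ in more than one place and neither carries a hydrogen atom on this nitrogen. The new pair shows that the entire side chain, with its five-membered aromatic ring and 7 heavy atoms, can be taken off this position without a clear shift in half-life, and nothing measured here offers an explanation for that outcome.

On these data alone, whether a small methyl group, a longer alkyl chain or a chain ending in an amine on this same nitrogen would move the number beyond the scatter remains open. The higher number of compound 2 also remains unexplained, since the halogen and the arrangement of the five-membered ring on its side chain have not been separated by a single-place step.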